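The source may report more compounds than this note shows. Statements on the series, on what has been measured and on what is new or still open speak of the compounds shown alone.

Compound 1 `CN1CCN(c2ccc(C3=NN(C(=O)c4ccc(C(F)(F)F)cc4)C(c4ccc(N(C)C)cc4)C3)cc2)CC1`: > 10000 nM
Compound 2 `CN1CCN(c2ccc(C3=NN(C(=O)/C=C/c4ccccc4)C(c4ccc(N(C)C)cc4)C3)cc2)CC1`: > 10000 nM

In a functional assay on A549 cells (Homo sapiens) for inhibition (a lower number here means a stronger inhibitor, a higher number a weaker inhibitor), compound 1 gives > 10000 nM, which is a limit of the assay and not a number. Compound 2 likewise gives > 10000 nM, again only a limit. The step that the two limits leave unreadable from compound 1 to compound 2 therefore cannot be read. Compound 3 `CN1CCN(c2ccc(C3=NN(S(=O)(=O)c4ccc(C#N)cc4)C(c4ccc(N(C)C)cc4)C3)cc2)CC1` differs from compound 1 by (4-cyanophenyl)sulfonyl in place of (4-(trifluoromethyl)phenyl)carbonyl on an amine nitrogen in a ring. For the measured compounds named here, no measured step bears directly on this change; the only evidence is the limit of > 10000 nM in this assay, at which 2 of the 2 values shown sit. Compound 3 is expected to remain at that limit, with an estimated step that the limit leaves unreadable from compound 1 to compound 3 and an estimate of 20000 nM, between 5000 nM and 100000 nM.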

Compound 3, half-maximal inhibitory concentration: 3600 nM
Estimate against measurement, compound 3: 5.6-fold (0.74 log units) above, and the stated range ends above it.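

For the compounds shown here, on the amine nitrogen in a ring, (4-cyanophenyl)sulfonyl gives the only number among the three compounds in this assay, with an at least 2.7-fold lower number from compound 1 to compound 3 (0.44 log units; beyond the scatter) and an at least 2.7-fold lower number from compound 2 to compound 3 (0.44 log units; beyond the scatter). So this position can respond to a change of group, and activity in these cells is within reach of the core. The comparison still rests on limits, not numbers: the limit of > 10000 nM in this assay, at which 2 of the 3 values shown sit.

Going by these compounds, whether the sulfonyl or the nitrile carries this step stays open, as the two enter together. On these data alone, how a methylsulfonyl or a (4-aminophenyl)sulfonyl group would read at this nitrogen is also open.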